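This account rests on a few compounds, and the source may have more. Where it says the series, first, only, none or still open, it means among the compounds named here.

In a functional assay on MCF7 cells (Homo sapiens) for inhibition, with a stated time of 48 h, tested at 50 uM (a higher number here means more inhibition of growth at the concentration tested, a lower number less inhibition of growth), compound 1 (`C=C[C@@](C)(/C=C/c1ccc(OC(=O)CC)cc1)CCC=C(C)C`) gives 23%, compound 2 (`C=C[C@@](C)(/C=C/c1ccc(OC(=O)CCC)cc1)CCC=C(C)C`) gives 20% and compound 3 (`C=C[C@@](C)(/C=C/c1ccc(OC(=O)CCCCC)cc1)CCC=C(C)C`) gives 18%. These numbers lie within the scatter of one another, so compound 3 cannot be told apart from the other two. Compound 4 (`C=C[C@@](C)(/C=C/c1ccc(OC(=O)CCCCCCCCCCCCCCC)cc1)CCC=C(C)C`) differs from compound 3 by decyl in place of hydrogen on a saturated chain carbon, five bonds along the chain from a carbonyl carbon. The closest evidence comes from the other chain extensions: a number 3 percentage points lower from compound 1 to compound 2 (within the scatter), a number 5 percentage points lower from compound 1 to compound 3 (within the scatter) and a number 2 percentage points lower from compound 2 to compound 3 (within the scatter), each within the scatter. Those steps added only methyl, propyl or ethyl, so decyl reaches well past anything measured, and the range must stay wide. The expected change is a number 3 percentage points lower from compound 3 to compound 4 (within the scatter), which would not exceed the scatter. The estimate for compound 4 is 15%, with a range of 5% to 27%.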

Compound 4, percent growth inhibition at one concentration: 24%
For compound 4 the middle estimate is 9 percentage points below the measured one, within the range that was stated.
By their numbers in this assay, from the lowest: compounds 3, 2, 1 and 4 (each within the scatter of the next).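

In this assay, decyl in place of hydrogen on a saturated chain carbon, five bonds along the chain from a carbonyl carbon, gives a number 6 percentage points higher from compound 3 to compound 4 (within the scatter), and dodecyl at the position three bonds along gives a number 4 percentage points higher from compound 2 to compound 4 (within the scatter). Even a chain far longer than the earlier ones therefore cannot be told apart from them in growth inhibition at the concentration tested. Going by these compounds, whether an amine or a carboxylic acid in place of decyl would give a step beyond the scatter stays open. No measurement at hand explains these results.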